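Sulfonyl aryl swap on a quinolinone core

The source may hold more compounds than are shown below. What is called first, only, known or untested is meant among the compounds shown, and "the series" means these compounds.

Measured so far:
Compound 1 `COc1ccc(-c2cc(=O)c3c(OC)cc(OC)cc3n2C)cc1` gives 28000 nM.
Compound 2 `COc1ccc(-c2cc(=O)c3c(OC)cc(OC)cc3n2S(=O)(=O)c2ccc(C#N)cc2)cc1` gives 7900 nM.

For the measured compounds named here, in a functional assay on SUP-B15 cells (Homo sapiens) for antiproliferative activity, with a stated time of 72 h (a lower number here means that less compound is needed, a higher number that more compound is needed for the effect), compound 2 holds the lowest of the two numbers; its nearest neighbour is compound 1, and the only step measured, a 3.5-fold lower number from compound 1 to compound 2 (0.55 log units; beyond the scatter), concerns the change on the aromatic nitrogen. Compound 3 `COc1ccc(-c2cc(=O)c3c(OC)cc(OC)cc3n2S(=O)(=O)c2c(F)c(F)c(F)c(F)c2F)cc1` has not been measured. It differs from compound 2 only in 2,3,4,5,6-pentafluorophenyl in place of 4-cyanophenyl on a sulfonyl sulfur. Going by the values given here, no measured step touches the aryl group on the sulfonyl sulfur, so nothing among the two numbers speaks for or against a change here; the step from compound 1 to compound 2 bears on the attachment at the nitrogen, not on the ring beyond the sulfonyl. Compound 3 is therefore expected to stay near compound 2, with a 1.1-fold lower number from compound 2 to compound 3 (0.05 log units; within the scatter) not beyond the scatter. The estimate for compound 3 in this assay is 7000 nM, with a range from 2500 nM to 20000 nM.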

Compound 3, half-maximal effective concentration: 4100 nM
Beside the measured number, compound 3's estimate is 1.7-fold (0.23 log units) above it, within the range that was stated.
By their numbers in this assay, from the lowest: compounds 3 and 2 (each within the scatter of the next); then compound 1.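

In this assay, for the compounds shown here, the aryl group on the sulfonyl sulfur is now varied for the first time, a point the step at the aromatic nitrogen could not address. With a 1.9-fold lower number from compound 2 to compound 3 (0.28 log units; within the scatter), 2,3,4,5,6-pentafluorophenyl takes the place of 4-cyanophenyl without a change beyond the scatter, so for this pair the nitrile is not needed to keep the number where it stands. Nothing available explains why the two aryl groups give readings within the scatter of each other.

A single exchange on the sulfonyl sulfur leaves open how a plain phenyl ring, or a phenyl ring bearing an amine or a carboxylic acid, would read in this assay. It also leaves open whether the aryl ring could give way to a simple alkyl chain such as butyl.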